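The source may hold more compounds than are shown below. What is called first, only, known or untested is meant among the compounds shown, and "the series" means these compounds.

Three compounds share one core and differ only in what sits on the amine nitrogen of the saturated six-membered ring. Compound 1 `Cc1cccc2c1nc(COc1ccc(Cl)cc1)n2CCCC1CCNCC1` carries hydrogen there; in an assay on AV12 cells for binding affinity to Neuropeptide Y receptor type 1 (Homo sapiens) (a higher number here means a weaker inhibitor, a lower number a stronger inhibitor), compound 1 gives 335 nM. Compound 2 `Cc1cccc2c1nc(COc1ccc(Cl)cc1)n2CCCC1CCN(CCCc2ccccc2)CC1` carries 3-phenylpropyl, and in this assay compound 2 gives 57 nM, a change of a 5.9-fold lower number from compound 1 to compound 2 (0.77 log units; beyond the scatter). Compound 3 `CCOC(=O)CCCN1CCC(CCCn2c(COc3ccc(Cl)cc3)nc3c(C)cccc32)CC1` carries 3-(ethoxycarbonyl)propyl; in this assay compound 3 gives 29 nM, the lowest number of the three, reached through a 12-fold lower number from compound 1 to compound 3 (1.06 log units; beyond the scatter), while the swap a 2.0-fold lower number from compound 2 to compound 3 (0.29 log units; within the scatter) lies within the scatter.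

Compound 4 `Cc1cccc2c1nc(COc1ccc(Cl)cc1)n2CCCC1CCN(C(=O)CCN2CCCCC2)CC1` brings the change ((2-(piperidin-1-yl)ethyl)carbonyl in place of 3-(ethoxycarbonyl)propyl on an amine nitrogen in a ring). The two earlier steps show that any of these groups on that nitrogen, whether ending in phenyl or in an ester, lowers the number well beyond the scatter relative to hydrogen, and that the two groups tried so far are not told apart. Among the measured compounds shown here, no measured step covers a carbonyl bound directly to this nitrogen, so the expectation rests on that nitrogen remaining substituted. A step of about a 2.1-fold higher number from compound 3 to compound 4 (0.32 log units; beyond the scatter) is expected, within the scatter, and compound 4 is estimated at 60 nM, between 15 nM and 300 nM.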

Compound 4, inhibition constant: 260 nM
Compound 4: middle estimate off by 4.3-fold (0.64 log units), on the low side; the range from low to high includes it.
By their numbers in this assay, from the lowest: compounds 3 and 2 (each within the scatter of the next); then compounds 4 and 1 (each within the scatter of the next).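

In this assay, the (2-(piperidin-1-yl)ethyl)carbonyl group does not match the two earlier groups on this amine nitrogen: replacing 3-(ethoxycarbonyl)propyl gives a 9.0-fold higher number from compound 3 to compound 4 (0.95 log units; beyond the scatter) and replacing 3-phenylpropyl gives a 4.6-fold higher number from compound 2 to compound 4 (0.66 log units; beyond the scatter) on the same nitrogen. Against plain hydrogen the step is a 1.3-fold lower number from compound 1 to compound 4 (0.11 log units; within the scatter), so among these compounds, having a group on this nitrogen does not by itself bring the lower numbers seen for compound 2 and compound 3. No supporting measurement explains this difference.

The new group changes both the atom bound to the nitrogen, now a carbonyl carbon, and the chain end, now a piperidine ring, so the two changes cannot be separated here. A 3-(piperidin-1-yl)propyl chain without the carbonyl, or a carbonyl-linked chain ending in phenyl, would help tell them apart.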